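Working notes: from compound 3 to compound 4

A few compounds are considered here, and "the series" means these few. Any claim that something is new, unique, unknown or untested is made for them only; others in the source may bear on it.

Values so far in a functional assay on HUVEC cells (Homo sapiens) for antiproliferative activity, read by MTT assay, with a stated time of 48 h (on this read-out higher numbers stand for weaker inhibition and lower numbers for stronger inhibition), by compound
compound 1 `O=[N+]([O-])c1ccccc1/C=C/c1nnc(-c2ccc3c(c2)OCCO3)o1` at 25000 nM
compound 2 `COc1ccc(/C=C/c2nnc(-c3ccc4c(c3)OCCO4)o2)cc1` at > 50000 nM as a limit of the assay, not a number
compound 3 `Fc1cccc(/C=C/c2nnc(-c3ccc4c(c3)OCCO4)o2)c1` at 3530 nM

Compound 3 at 3530 nM holds the lower of the two actual numbers, and compound 1 at 25000 nM lies higher, beyond the scatter. Compound 2 at > 50000 nM gives only a limit.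

For compound 4 `Cc1ccccc1/C=C/c1nnc(-c2ccc3c(c2)OCCO3)o1` the counted difference 2-methylphenyl in place of 3-fluorophenyl on a double-bonded chain carbon bound to a double-bonded chain carbon brings 2-methylphenyl in place of 3-fluorophenyl on a double-bonded chain carbon bound to a double-bonded chain carbon. Within the data shown here, at this same place the one measured step is an at least 14-fold lower number from compound 2 to compound 3 (1.15 log units; beyond the scatter) and it is large, so a swap here has already moved the number far once in this assay for this series. As far as these compounds go, that step starts from the limit of > 50000 nM in this assay, at which 1 of the 3 values shown sits, and its full size stays open.

Compound 3 at 3530 nM has the lowest number shown, with no other compound near it, so a rise is the likelier direction. An estimated step of a 3.4-fold higher number from compound 3 to compound 4 (0.53 log units; beyond the scatter) is expected, smaller than the measured one but probably beyond the scatter. For compound 4 the expected value is 12000 nM with 3000 nM to 45000 nM as the estimated range.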

Compound 4, half-maximal inhibitory concentration: 40500 nM
For compound 4 the middle estimate is 3.4-fold (0.53 log units) below the measured one; measured number inside the range.
By their numbers in this assay, from the lowest: compound 3; then compounds 1 and 4 (each within the scatter of the next). At a limit, above all of these: compound 2.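

In this assay 2-methylphenyl in place of 3-fluorophenyl on a double-bonded chain carbon bound to a double-bonded chain carbon gives an 11-fold higher number from compound 3 to compound 4 (1.06 log units; beyond the scatter), a large step, even though the leaving and entering groups match in the counts computed for them: heavy atoms, aromatic ring, hydrogen-bond donors and acceptors, and net charge, so a large shift here is now read between two actual numbers and does not rest on a limit. The step of a 1.6-fold higher number from compound 1 to compound 4 (0.21 log units; within the scatter) lies within the scatter, so methyl in place of nitro on an aromatic carbon gives no order between these two compounds, and neither group brings the number close to that of compound 3. The step of an at least 1.2-fold lower number from compound 2 to compound 4 (0.09 log units; that floor lies within the scatter) is known only as a floor, and that floor lies within the scatter. Compound 2 gives only a limit of the assay: the limit of > 50000 nM in this assay, at which 1 of the 4 values shown sits.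

Because 2-methylphenyl in place of 3-fluorophenyl changes both the group on the ring and the name's ring number, the large step does not separate these two changes; 3-methylphenyl and 2-fluorophenyl would bear directly on that. As far as these compounds go, whether the low number of compound 3 is particular to fluorine also stays open, and 3-chlorophenyl or 3-aminophenyl at this place would test it.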